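A few compounds are considered here, and "the series" means these few. Any claim that something is new, unique, unknown or untested is made for them only; others in the source may bear on it.

Measured in a functional assay on PC-3 cells (Homo sapiens) for inhibition, read by sulforhodamine B assay, with a stated time of 48 h, tested at 10 uM; on this read-out higher numbers stand for more inhibition of growth at the one concentration tested and lower numbers for less inhibition of growth:
- Compound 1 `COc1ccc(-c2nc3sc(-c4ccccc4)cn3n2)cc1`: 33%
- Compound 2 `C/C(=N/O)c1ccc(NC(=O)Cn2nc(C(F)(F)F)nc2N)cc1`: 20.3%
- Compound 3 `COc1cc(-c2nc3sc(-c4ccccc4)cn3n2)cc(OC)c1OC`: 53%

Compound 1 stands second highest of the three, with compound 2 lower and compound 3 higher, both beyond the scatter. Compound 4 `COc1ccc(-c2nc3sc(-c4ccc(Cl)cc4)cn3n2)cc1` differs from compound 1 by chloro in place of hydrogen on an aromatic carbon, the same difference reading phenyl to 4-chlorophenyl. Within the data shown here, no measured pair isolates this change, so the expectation stays close to compound 1 at 33%. In this assay a small upward step, not beyond the scatter, is expected. The expected move is a number 5 percentage points higher from compound 1 to compound 4 (within the scatter). Compound 4 is estimated at 38%, with an expected range of 22% to 55%.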

Compound 4, percent growth inhibition at one concentration: 41.9%
For compound 4 the middle estimate is 3.9 percentage points below the measured one; low and high end bracket the measured number.
By their numbers in this assay, from the lowest: compound 2; then compounds 1 and 4 (each within the scatter of the next); then compound 3.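

In this assay, among these compounds, phenyl to 4-chlorophenyl gives a number 8.9 percentage points higher from compound 1 to compound 4 (within the scatter), the first step that isolates a single change. The position on the aromatic ring, para to a large group, therefore accepts chloro with no loss of growth inhibition, but no gain can be claimed from this step. No measured evidence bears on this result.

As far as these compounds go, whether a fluoro, a hydroxyl or an amine at this same position would move the number beyond the scatter remains open. So does whether chloro in place of hydrogen has a similar effect on compound 3.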